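Swapping fluorine for chlorine on a pyrazole-linked phenyl ring

A few compounds are considered here, and "the series" means these few. Any claim that something is new, unique, unknown or untested is made for them only; others in the source may bear on it.

Compound 1 `COc1cc(N/C=C\C(=O)c2cn(-c3ccccc3)nc2-c2ccc(F)cc2)cc(OC)c1OC` carries a trimethoxyphenyl amine and a 4-fluorophenyl group on the shared core. In a functional assay on A549 cells (Homo sapiens) for antiproliferative activity, read by MTT assay, with a stated time of 48 h (a lower number here means a stronger inhibitor, a higher number a weaker inhibitor), compound 1 gives 9350 nM. Compound 2 `O=C(/C=C\Nc1ccc(F)cc1)c1cn(-c2ccccc2)nc1-c1ccc(Cl)cc1` differs from compound 1 in more than one place, so the difference between the two cores is not broken down here. Compound 2 reaches only the limit > 50000 nM in this assay (the limit of > 50000 nM in this assay, at which 1 of the 3 values shown sits). Compound 3 `O=C(/C=C\Nc1ccc(Cl)cc1)c1cn(-c2ccccc2)nc1-c1ccc(Cl)cc1` gives 3670 nM. The change from compound 2 to compound 3 is chloro in place of fluoro on an aromatic carbon, and it brought an at least 13-fold lower number from compound 2 to compound 3 (1.13 log units; beyond the scatter).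

Compound 4 `COc1cc(N/C=C\C(=O)c2cn(-c3ccccc3)nc2-c2ccc(Cl)cc2)cc(OC)c1OC` has not been measured. It arises from compound 1 by chloro in place of fluoro on an aromatic carbon, the same change at the same kind of place, although the wider cut reads only 4-fluorophenyl to 4-chlorophenyl here, without the amino part. Because the large step of an at least 13-fold lower number from compound 2 to compound 3 (1.13 log units; beyond the scatter) sits on the amine ring rather than this one, a smaller step is expected from compound 1 to compound 4, a 1.9-fold lower number from compound 1 to compound 4 (0.27 log units; within the scatter). Compound 4 is estimated at 5000 nM, within 1500 nM to 20000 nM.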

Compound 4, half-maximal inhibitory concentration: 5640 nM
The estimate for compound 4 lay 1.1-fold (0.05 log units) below the measured number, and the stated range covers the measured number.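

In this assay, chloro in place of fluoro on the 4-fluorophenyl group brought a 1.7-fold lower number from compound 1 to compound 4 (0.22 log units; within the scatter), so in this pair the swap cannot be told apart from the ordinary spread of repeated measurements. Carried to the other pair, where it sits on the amine ring and the rest of the molecule also differs, the same swap does not keep its size: the same change on two cores in this assay, an at least 13-fold lower number (1.13 log units; beyond the scatter) from compound 2 to compound 3 and a 1.7-fold lower number (0.22 log units; within the scatter) from compound 1 to compound 4, at least 8.2-fold (0.91 log units) apart, beyond the scatter of two such steps. What this does not show is which of those differences matters, and the larger step has no upper end, as compound 2 stands at a limit of the assay rather than at a number: the limit of > 50000 nM in this assay, at which 1 of the 4 values shown sits.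

Still open, as far as these compounds go, is whether the swap on the amine ring would give a large step if the other phenyl ring carried fluoro rather than chloro. Also open, from the compounds shown here alone, is how a bromo, methyl or nitrile group in place of the chloro would read in this assay.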